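From cyclobutyl to thiophen-2-yl in compound 1

The source may report more compounds than this note shows. Statements on the series, on what has been measured and on what is new or still open speak of the compounds shown alone.

In a physicochemical assay for solubility, at pH 7 (a lower number here means a less soluble compound, a higher number a more soluble compound), compound 1 (`CN1CCC(C(=O)N2Cc3c(NC(=O)C4CCC4)n[nH]c3C2(C)C)CC1`) reads > 225000 nM, which is a limit of the assay and not a number. Compound 2 (`CC(C)(C)C(=O)N1Cc2c(NC(=O)c3ccc(F)cc3)n[nH]c2C1(C)C`) gives an actual number, 235000 nM. Compound 3 (`CN1CCC(C(=O)N2Cc3c(NC(=O)c4cccs4)n[nH]c3C2(C)C)CC1`) carries thiophen-2-yl in place of cyclobutyl on a carbonyl carbon. Among the compounds with values here, no measured pair shows this change, so only a small downward move in this assay is expected, probably within the usual scatter, with an at least 1.1-fold lower number from compound 1 to compound 3 (0.05 log units; that floor lies within the scatter) as the estimated step. For compound 3 the expected value is 200000 nM, with an estimated range of 90000 nM to 320000 nM.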

Compound 3, solubility: 155000 nM
Compound 3: the middle estimate sits 1.3-fold (0.11 log units) above what was measured; measured number inside the range.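

Thiophen-2-yl in place of cyclobutyl on a carbonyl carbon now has a reading in this assay, and the step is an at least 1.4-fold lower number from compound 1 to compound 3 (0.16 log units; that floor lies within the scatter). Within the data shown here, with compound 3, this position on the core of compound 1 carries an actual number for the first time. The step is only a floor, as the reading for compound 1 is a limit and not a number: the limit of > 225000 nM in this assay, at which 1 of the 3 values shown sits.

As far as these compounds go, the true size of the step stays open. Also open, from the compounds shown here alone, is how this position reads with a group bearing an amine or a carboxylic acid in place of thiophen-2-yl.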